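Methoxy added to the aromatic ring of compound 2

This account rests on a few compounds, and the source may have more. Where it says the series, first, only, none or still open, it means among the compounds named here.

Compound 1 `COc1cccc2c1CCCC2CN1CCN(C2CCCCC2)CC1`: 0.31 nM
Compound 2 `c1ccc2c(c1)CCCC2CCCN1CCN(C2CCCCC2)CC1`: 0.61 nM
Compound 3 `COc1ccc2c(c1)CCCC2CCCN1CCN(C2CCCCC2)CC1`: 0.36 nM

In an assay on membranes from brain (Cavia porcellus) for binding affinity to Sigma non-opioid intracellular receptor 1 (Homo sapiens) (a higher number here means a weaker inhibitor, a lower number a stronger inhibitor), compound 2 gives the highest of the three numbers, though its gaps to compound 3 and compound 1 are both within the scatter. Compound 4 `COc1ccc2c(c1)C(CCCN1CCN(C3CCCCC3)CC1)CCC2` differs from compound 2 by methoxy in place of hydrogen on an aromatic carbon. For the measured compounds named here, the one measured step that bears on this change is a 1.7-fold lower number from compound 2 to compound 3 (0.23 log units; within the scatter), where the same group entered the same ring at another carbon, and the number barely moved. On that basis the expected step of a 1.4-fold lower number from compound 2 to compound 4 (0.13 log units; within the scatter) is small, with no shift beyond the scatter. Compound 4 is therefore estimated at 0.45 nM, with a likely range from 0.2 nM to 1.2 nM.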

Compound 4, inhibition constant: 9.04 nM
Compound 4: middle estimate off by 20-fold (1.30 log units), on the low side; the measured number lies above the stated range.
By their numbers in this assay, from the lowest: compounds 1, 3 and 2 (each within the scatter of the next); then compound 4.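

In this assay methoxy at another carbon of the same ring, in compound 3, left the number within the scatter, yet at this carbon, meta to a fused ring and para to a fused ring, it gives a 15-fold higher number from compound 2 to compound 4 (1.17 log units; beyond the scatter) in a large step. The printed values make the contrast plain: compound 3 gives 0.36 nM and compound 4 gives 9.04 nM with the same group on the same ring. So the outcome of this change depends on which aromatic carbon carries the methoxy, and no measurement at hand explains why. On these data alone, whether a hydroxyl or a chlorine atom at this carbon would shift the number as methoxy does remains open.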